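A few compounds are considered here, and "the series" means these few. Any claim that something is new, unique, unknown or untested is made for them only; others in the source may bear on it.

In an ADME assay on CRFK cells (Felis catus) for cytotoxicity (on this read-out higher numbers stand for lower toxicity in this test and lower numbers for higher toxicity in this test), compound 1 `CCN(CC)CN1C(=O)/C(=N/NC(=S)Nc2ccccc2)c2cc(Cl)ccc21` gives 6900 nM. Compound 2 `CCN(CC)CN1C(=O)/C(=N/NC(=S)Nc2ccc(Cl)cc2)c2ccccc21` gives 4000 nM. Compound 1 has the higher of these two numbers, but the two values lie within the usual scatter of each other, so they do not separate the compounds. The next compound to be tested is compound 3 `CCN(CC)CN1C(=O)/C(=N/NC(N)=S)c2cc(Cl)ccc21`, which has not yet been measured. It differs from compound 1 by hydrogen in place of phenyl on an amide-type nitrogen. Among the compounds with values here, no measured pair shows what this exchange does, so the expectation rests on judgement and remains loose. A moderate move to a higher number in this assay, meaning lower toxicity in this test, is expected, and a change within the scatter would not surprise. The expected change is a 1.9-fold higher number from compound 1 to compound 3 (0.28 log units; within the scatter). Compound 3 is estimated at 13000 nM, with an expected range of 4500 nM to 40000 nM.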

Compound 3, half-maximal cytotoxic concentration: > 100000 nM
Compound 3 gave a limit, no number; the forecaster's own chance of this, stated with the estimate: 15%; middle value at least 7.6-fold (0.88 log units) away from the limit.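

In this assay, within the data shown here, hydrogen in place of phenyl on the amide-type nitrogen gives an at least 14-fold higher number from compound 1 to compound 3 (1.16 log units; beyond the scatter), the first step at this position and a large one. For compound 3, > 100000 nM is a limit of the assay and not a number, so the step fixes only a minimum for the change and not its true size: the limit of > 100000 nM in this assay, at which 1 of the 3 values shown sits. In this single pair, the anilino group on the thiocarbonyl carbon therefore goes with much higher toxicity in this test than the amino group does.

As far as these compounds go, it remains open whether a small group such as methyl, a longer chain such as butyl or a saturated ring such as cyclohexyl on this nitrogen would read like compound 1 or like compound 3. From the compounds shown here alone, whether the same exchange would do the same on the core of compound 2 is also open.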